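Adding a Chlorine to a Compound at the Assay Limit

This account rests on a few compounds, and the source may have more. Where it says the series, first, only, none or still open, it means among the compounds named here.

Compound 1 `CC1(C)Cc2c(ccc(C(=O)/C=C/c3cn(-c4ccccc4)nc3-c3ccccc3)c2OCc2ccccc2)O1` was examined in a functional assay on HT-29 cells (Homo sapiens) for antiproliferative activity, read by MTT assay, with a stated time of 48 h; a lower number here means a stronger inhibitor, a higher number a weaker inhibitor. In this assay compound 1 gives > 100000 nM, which is a limit of the assay rather than a measured number. Two related compounds tell the same story. Compound 2 `CC1(C)Cc2c(OCc3ccccc3)ccc(C(=O)/C=C/c3cn(-c4ccccc4)nc3-c3ccc([N+](=O)[O-])cc3)c2O1` carries a nitro group on one of its phenyl rings; in this assay compound 2 gives > 100000 nM, again a limit. Compound 3 `CC1(C)Cc2c(ccc(C(=O)/C=C/c3ccc(Cl)cc3)c2OCc2ccccc2)O1` is a simpler analogue; in this assay compound 3 gives > 100000 nM, also a limit. Going by the values given here, every value so far is the limit of > 100000 nM in this assay, at which 3 of the 3 values shown sit.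

Compound 4 `CC1(C)Cc2c(ccc(C(=O)/C=C/c3cn(-c4ccccc4)nc3-c3ccc(Cl)cc3)c2OCc2ccccc2)O1` differs from compound 1 by chloro in place of hydrogen on an aromatic carbon. Among the compounds with values here, no pair of measured compounds shows what such a change does here. Since compound 1 sits at the limit with > 100000 nM, and compound 3, which also carries a chloro group, gives > 100000 nM, the step from compound 1 to compound 4 is expected to be a number no higher from compound 1 to compound 4 (the limit leaves the size open), meaning no change beyond the scatter. Compound 4 is therefore estimated at 100000 nM, within 30000 nM to 300000 nM, and most likely reported again only as a limit.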

Compound 4, half-maximal inhibitory concentration: > 100000 nM
Compound 4: no number, only a limit; the forecaster's own chance of this, stated with the estimate: 75%; the middle value sits exactly at the limit.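

Going by these compounds alone, compound 4 gives > 100000 nM in this assay, which is a limit and not a number, so no step from compound 1 to compound 4 can be read. The compounds shown leave open what going from phenyl to 4-chlorophenyl does to activity, since none of them gives a measured number: the limit of > 100000 nM in this assay, at which 4 of the 4 values shown sit.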